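Two Measured Limits and One Expected Value

The source may report more compounds than this note shows. Statements on the series, on what has been measured and on what is new or still open speak of the compounds shown alone.

compound 1 `CCc1ccc2[nH]c(=O)c(CN(Cc3ccc(F)cc3)Cc3ccc4ccccc4c3)cc2c1`: > 5000 nM
compound 2 `COc1ccc(CN(Cc2ccc(C(C)(C)C)cc2)Cc2cc3cc(C)ccc3[nH]c2=O)cc1`: > 10000 nM

In a toxicity assay on MDCK cells (Canis lupus familiaris) for cytotoxicity, read by crystal violet staining, with a stated time of 48 h (a higher number here means that more compound is tolerated, a lower number that less compound is tolerated), compound 1 shows only a limit, > 5000 nM. Compound 2 likewise shows only a limit, > 10000 nM, so no number stands for it, only (the limit of > 10000 nM in this assay, at which 1 of the 2 values shown sits). Compound 3 `Cc1ccc2[nH]c(=O)c(CN(Cc3ccc(C(C)(C)C)cc3)C(C)c3ccc(OC(F)F)cc3)cc2c1` differs from compound 2 in one place: 1-(4-(difluoromethoxy)phenyl)ethyl in place of 4-methoxybenzyl on an amine nitrogen. Among the measured compounds shown here, no step between measured compounds is available, so the expected step is a number no higher from compound 2 to compound 3 (the limit leaves the size open), within the scatter, in this assay. Compound 3 is therefore expected to give 10000 nM, between 4000 nM and 25000 nM.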

Compound 3, half-maximal cytotoxic concentration: > 5000 nM
Compound 3: a limit, no number; the forecaster's own chance of this, stated with the estimate: 70%; the middle value is on the limit's open side.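

Compound 2 and compound 3 each give only a limit in this assay, so no step can be read between them. The compounds shown leave open at what concentration any of them harms the cells.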